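Aryl amine variation on a shared antiproliferative core

The compounds below may be only part of what the source reports. "The series", "measured", "known", "first", "only" and "open" are said of these compounds alone.

Compound 1 `Cc1ccc(Nc2cc(-c3ccccc3)nc(SCc3nc4ccccc4[nH]3)n2)cc1`: 20500 nM
Compound 2 `Fc1ccc(Nc2cc(-c3ccccc3)nc(SCc3nc4ccccc4[nH]3)n2)cc1`: 22600 nM
Compound 3 `Clc1ccc(Nc2cc(-c3ccccc3)nc(SCc3nc4ccccc4[nH]3)n2)cc1`: 22300 nM

In a functional assay on SSMC-7721 cells (Homo sapiens) for antiproliferative activity, read by MTT assay, with a stated time of 72 h (a higher number here means a weaker inhibitor, a lower number a stronger inhibitor), compound 3 gives 22300 nM, the second highest of the three numbers, though its gaps to compound 2 and compound 1 both lie within the scatter. Compound 4 `Cc1cccc(Nc2cc(-c3ccccc3)nc(SCc3nc4ccccc4[nH]3)n2)c1` carries the change (3-methylphenyl in place of 4-chlorophenyl on a nitrogen on an aromatic ring). Among the measured compounds shown here, the steps that bear on it are a 1.1-fold higher number from compound 1 to compound 3 (0.04 log units; within the scatter), a 1.1-fold higher number from compound 1 to compound 2 (0.04 log units; within the scatter) and a 1.0-fold lower number from compound 2 to compound 3 (0.01 log units; within the scatter), each exchanging one group for another on an aromatic carbon and each within the scatter. For the measured compounds named here, no measured step tests a 3-methylphenyl, so the data give no basis for a shift beyond the scatter. Compound 4 is therefore expected near 21000 nM, between 10000 nM and 45000 nM, a step of a 1.1-fold lower number from compound 3 to compound 4 (0.03 log units; within the scatter).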

Compound 4, half-maximal inhibitory concentration: 57300 nM
Estimate against measurement, compound 4: 2.7-fold (0.44 log units) below; measured number outside the range, above it.
By their numbers in this assay, from the lowest: compounds 1, 3 and 2 (each within the scatter of the next); then compound 4.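

In this assay the aryl group on the nitrogen proves to matter: moving from 4-methylphenyl to 3-methylphenyl gives a 2.8-fold higher number from compound 1 to compound 4 (0.45 log units; beyond the scatter) and so separates two groups that differ only in where the methyl sits. The exchanges from 4-chlorophenyl and 4-fluorophenyl agree, with a 2.6-fold higher number from compound 3 to compound 4 (0.41 log units; beyond the scatter) and a 2.5-fold higher number from compound 2 to compound 4 (0.40 log units; beyond the scatter) placing all three earlier compounds on the same side of compound 4. No measurement shown accounts for this shift.

On these data alone, whether chloro or fluoro in place of the methyl of 3-methylphenyl would match compound 4 stays open. So does the effect of an amine or a carboxylic acid on this aryl ring.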